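This account rests on a few compounds, and the source may have more. Where it says the series, first, only, none or still open, it means among the compounds named here.

Measured in a functional assay on A549 cells (Homo sapiens) for antiproliferative activity, read by MTT assay, with a stated time of 72 h; on this read-out lower numbers stand for stronger inhibition and higher numbers for weaker inhibition:
- Compound 1 `O=C(N/N=C/c1ccc(F)cc1)Nc1ccc(Oc2ccnc3[nH]ccc23)c(F)c1`: 680 nM
- Compound 2 `O=C(N/N=C/c1ccc([N+](=O)[O-])cc1)Nc1ccc(Oc2ccnc3[nH]ccc23)c(F)c1`: 20 nM
- Compound 3 `COc1ccc(/C=N/NC(=O)Nc2ccc(Oc3ccnc4[nH]ccc34)c(F)c2)cc1`: 3980 nM

Compound 1 holds the middle place of these three numbers, with compound 2 lower and compound 3 higher. Compound 4 `O=C(N/N=C/c1ccc(F)cc1)Nc1ccc(Oc2ccnc3[nH]ccc23)cc1` has not been measured yet. It differs from compound 1 by a single change, hydrogen in place of fluoro on an aromatic carbon.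

The measured steps show that swapping one group on an aromatic carbon can move the number a long way: a 34-fold lower number from compound 1 to compound 2 (1.53 log units; beyond the scatter), a 5.9-fold higher number from compound 1 to compound 3 (0.77 log units; beyond the scatter) and a 200-fold higher number from compound 2 to compound 3 (2.30 log units; beyond the scatter). However, all of them swap a different group. Among the measured compounds shown here, the fluoro that leaves in compound 4 stays unchanged in compounds 1, 2 and 3, so no measured step tests this change directly. These steps give no direction for it, so no step beyond the scatter is expected, though a wide range remains sensible.

The expected result is a 1.2-fold higher number from compound 1 to compound 4 (0.07 log units; within the scatter). For compound 4 the estimated value is 800 nM, with an expected range of 250 nM to 2600 nM.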

Compound 4, half-maximal inhibitory concentration: 1430 nM
The estimate for compound 4 lay 1.8-fold (0.25 log units) below the measured number; low and high end bracket the measured number.
By their numbers in this assay, from the lowest: compound 2; then compound 1; then compound 4; then compound 3.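

Among the compounds shown here, this is the first measured change at this fluoro, which sits on a six-membered aromatic ring of carbon only, ortho to a large group and meta to a large group. In this assay, hydrogen in its place gives a 2.1-fold higher number from compound 1 to compound 4 (0.32 log units; beyond the scatter), so in this pair the fluoro goes with the lower number, though the step is modest and much smaller than a 34-fold lower number from compound 1 to compound 2 (1.53 log units; beyond the scatter), where nitro replaces the other fluoro. No measurement at hand explains why removing this fluoro raises the number.

Going by these compounds, this reading rests on a single pair, so it remains open whether hydrogen in place of this fluoro would give a similar step in compound 2 or compound 3, which carry nitro and methoxy. On these data alone, how a chloro, a methyl or an amine would compare at this place also remains open.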